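From 3-chlorophenyl to 3-hydroxyphenyl: working notes

The source may hold more compounds than are shown below. What is called first, only, known or untested is meant among the compounds shown, and "the series" means these compounds.

Compound 1 `CC1(C)[C@H]2CC[C@]1(C)N(Cc1cn(-c3ccc(C#N)cc3)nn1)C(=O)C2` gives 500 nM in a functional assay on SGC-7901 cells (Homo sapiens) for inhibition, read by MTT assay, with a stated time of 24 h (on this read-out higher numbers stand for weaker inhibition and lower numbers for stronger inhibition), and compound 2 `CC1(C)[C@H]2CC[C@]1(C)N(Cc1cn(-c3ccccc3C#N)nn1)C(=O)C2` gives 260 nM there. Compound 3 `CC1(C)[C@H]2CC[C@]1(C)N(Cc1cn(-c3cccc(Cl)c3)nn1)C(=O)C2` gives 510 nM and so stands within the scatter of both, with a 1.0-fold higher number from compound 1 to compound 3 (0.01 log units; within the scatter) and a 2.0-fold higher number from compound 2 to compound 3 (0.29 log units; within the scatter) as its steps. Compound 4 `CC1(C)[C@H]2CC[C@]1(C)N(Cc1cn(-c3cccc(O)c3)nn1)C(=O)C2` carries hydroxy in place of chloro on an aromatic carbon as its change, hydroxy in place of chloro on an aromatic carbon. Among the measured compounds shown here, no measured step makes this exchange. The measured substituent swaps (a 1.9-fold lower number from compound 1 to compound 2 (0.28 log units; within the scatter) and the two above) all stay within the scatter, so no step beyond the scatter is expected in this assay and no direction is favoured. The expected value for compound 4 is 500 nM in an estimated range of 200 nM to 1300 nM as the likely span. The estimated 1.0-fold lower number from compound 3 to compound 4 (0.01 log units; within the scatter) stays inside the scatter.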

Compound 4, half-maximal inhibitory concentration: 270 nM
Estimate against measurement, compound 4: 1.9-fold (0.27 log units) above, within the range that was stated.
By their numbers in this assay, from the lowest: compounds 2, 4, 1 and 3 (each within the scatter of the next).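

Hydroxy in place of chloro on an aromatic carbon gives a 1.9-fold lower number from compound 3 to compound 4 (0.28 log units; within the scatter) in this assay and so stays within the scatter, which shows that this position accepts a group with a hydrogen-bond donor and acceptor without a step beyond the scatter. The 3-hydroxyphenyl group also stays within the scatter of both cyanophenyl groups, with a 1.0-fold higher number from compound 2 to compound 4 (0.02 log units; within the scatter) and a 1.9-fold lower number from compound 1 to compound 4 (0.27 log units; within the scatter) as its steps. Nothing available bears on the reason for these numbers.

On these data alone, whether an amine, a carboxylic acid or a methoxy group at this position would give a step beyond the scatter remains open.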